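Aryl Variation on a Shared Core Against Adenosine A3

The compounds below may be only part of what the source reports. "The series", "measured", "known", "first", "only" and "open" are said of these compounds alone.

Three measured compounds share one core and differ only in the aromatic group attached at a single carbon. Compound 1 `CC(C)(C)Cc1c(-c2ccoc2)sc(N)c1C(=O)c1ccc(Cl)cc1` carries a furan-3-yl there, compound 2 `CC(C)(C)Cc1c(-c2cccc(F)c2F)sc(N)c1C(=O)c1ccc(Cl)cc1` a 2,3-difluorophenyl, and compound 3 `CC(C)(C)Cc1c(-c2ccc(Cl)cc2)sc(N)c1C(=O)c1ccc(Cl)cc1` a 4-chlorophenyl. In an assay on CHO cells for displacement of a labelled ligand from adenosine receptor A3 (Homo sapiens), read by scintillation counting, tested at 10 uM (a lower number here means less inhibition, a higher number more inhibition at the concentration tested (going by the name of the read-out)), compound 1 gives 1%, compound 2 gives 1%, and compound 3 gives 1%. The steps of no change at the digits printed from compound 1 to compound 2 (within the scatter), no change at the digits printed from compound 1 to compound 3 (within the scatter) and no change at the digits printed from compound 2 to compound 3 (within the scatter) show that none of these exchanges moved the read-out, so compound 3 stands level with compounds 1 and 2 at the digits reported.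

Compound 4 `Cc1ccccc1-c1sc(N)c(C(=O)c2ccc(Cl)cc2)c1CC(C)(C)C` differs from compound 3 in one place: 2-methylphenyl in place of 4-chlorophenyl on an aromatic carbon. All three measured steps bear on this change, since each of them also swaps one aromatic group for another at the same carbon, and each of them was flat within the scatter. Compound 4 is therefore expected to show a number 1 percentage points higher from compound 3 to compound 4 (within the scatter), no movement beyond the scatter. For compound 4 an inhibition of 2% is estimated, with a range from -8% to 12%.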

Compound 4, a percentage reported as inhibition, at one concentration (the size of the read-out at that concentration, not a potency): 1%
For compound 4 the middle estimate is 1 percentage points above the measured one, and the stated range covers the measured number.
By their numbers in this assay, from the lowest: compounds 1, 2, 3 and 4 (each within the scatter of the next).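

With 2-methylphenyl at this carbon, this assay again shows no response to the aromatic group: the steps read no change at the digits printed from compound 3 to compound 4 (within the scatter) and no change at the digits printed from compound 2 to compound 4 (within the scatter) and no change at the digits printed from compound 1 to compound 4 (within the scatter). The new compound extends the flat series to a phenyl group that carries a methyl group and no halogen, and the exchange for 4-chlorophenyl replaces chlorine with carbon at the same position next to the ring sulfur. No supporting evidence bears on this result.

The compounds shown leave open whether any group at this carbon can move the read-out, since all of them carry an aromatic ring there, so an amine, a carboxylic acid or a longer chain remains untested in this account. They also say nothing about exchanges at the neopentyl, amino or (4-chlorophenyl)carbonyl groups.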